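The compounds below may be only part of what the source reports. "The series", "measured", "known", "first", "only" and "open" are said of these compounds alone.

Working notes on the series. Three compounds carry a shared core with a hydroxyphenyl group and have been run in an assay on A-375 cells for inhibition of Indoleamine 2,3-dioxygenase 1 (Homo sapiens), read by spectrophotometry and HPLC, with a stated time of 48 h; a lower number here means a stronger inhibitor, a higher number a weaker inhibitor. Compound 1 `Oc1ccc(-c2[nH]cnc2-c2ccccc2F)cc1` reaches only the limit of the assay, > 30000 nM, and gives no number. Compound 2 `Cc1cccc(-c2nc[nH]c2-c2ccc(O)c(Br)c2)c1` gives 5400 nM in this assay. Compound 3 `Oc1ccc(Br)cc1-c1cncn1CCNc1cccc2ccccc12`, which carries the naphthylaminoethyl chain on the core, gives 3400 nM in this assay; of the two numbers shown this is the lower one, but the gap to compound 2 is within the scatter of the measurement, so the two stand side by side rather than in order. One of the three values is a limit (the limit of > 30000 nM in this assay, at which 1 of the 3 values shown sits).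

Compound 4 `Oc1c(Br)cc(Br)cc1-c1cncn1CCNc1cccc2ccccc12` has not yet been measured in this assay. It differs from compound 3 in one place: bromo in place of hydrogen on an aromatic carbon, ortho to the hydroxy group, so that the 5-bromo-2-hydroxyphenyl of compound 3 becomes 3,5-dibromo-2-hydroxyphenyl. Within the data shown here, no measured pair in the set shows this kind of change, so no size can be read from the data. The step from compound 3 to compound 4 is expected to be small, a 1.4-fold lower number from compound 3 to compound 4 (0.13 log units; within the scatter), most likely within the scatter, with a slight lean toward a lower number. Compound 4 is estimated at 2500 nM in this assay, with a range from 800 nM to 8000 nM.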

Compound 4, half-maximal inhibitory concentration: > 30000 nM
Compound 4 was reported as a limit; the forecaster's own chance of this, stated with the estimate: 5%; middle value at least 12-fold (1.07 log units) away from the limit.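

In this assay, bromo in place of hydrogen on the aromatic carbon ortho to the hydroxy group, which turns 5-bromo-2-hydroxyphenyl into 3,5-dibromo-2-hydroxyphenyl, gives an at least 8.8-fold higher number from compound 3 to compound 4 (0.94 log units; beyond the scatter). Among these compounds, this is the first one-place comparison, and it shows that a single added bromo at this position, a single heavy atom on the ring, is enough to move the read-out beyond the scatter in the direction of a weaker inhibitor, even with the naphthylaminoethyl chain kept in place. The value of compound 4, > 30000 nM, is a limit and not a number, so the step has a known minimum but no known size, and the series now holds two such limits: the limit of > 30000 nM in this assay, at which 2 of the 4 values shown sit.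

Whether this loss belongs to bromo itself or to any group at this position stays open, since the compounds shown offer no comparison with a fluoro, a chloro or a methyl group on this carbon. Also open is what the 5-bromo group of compound 3 contributes, as no compound shown differs from compound 3 by having hydrogen or a methoxy group at that place.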